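Adding a Carboxy Group to a Cyclopentenone Cytotoxicity Series

The source may hold more compounds than are shown below. What is called first, only, known or untested is meant among the compounds shown, and "the series" means these compounds.

Of the compounds shown here, three built on a shared core have been tested in an ADME assay on HEp-2 cells (Homo sapiens) for cytotoxicity, read by MTT assay, with a stated time of 72 h; a higher number here means a weaker inhibitor, a lower number a stronger inhibitor. Compound 1 `COc1ccc(C2=C(c3cc(OC)c(OC)c(OC)c3)C(=O)C(OC(C)=O)C2)cc1F` gives < 1 ug/mL, a limit of the assay rather than a number. Compound 2 `COC(=O)c1cc(C2=C(c3cc(OC)c(OC)c(OC)c3)C(=O)CC2O[SiH2]C(C)(C)C)ccc1OC` gives > 100 ug/mL, again a limit. Compound 3 `COc1ccc(C2=C(c3cc(OC)c(OC)c(OC)c3)C(=O)CC2O)cc1` gives > 100 ug/mL, which is also a limit and not a measured number. So compound 3 stands at the weak end of what this assay can report, sitting at the limit of > 100 ug/mL in this assay, at which 2 of the 3 values shown sit, together with compound 2, while compound 1 sits at the limit of < 1 ug/mL in this assay, at which 1 of the 3 values shown sits.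

Compound 4 `COc1cc(C2=C(c3ccc(OCC(=O)O)cc3)C(O)CC2=O)cc(OC)c1OC` has not yet been measured. It differs from compound 3 in one place: carboxy in place of hydrogen on a saturated chain carbon bound to an oxygen on an aromatic ring. Going by the values given here, no step between measured compounds is available to say how such a change shifts the read-out, so the expectation rests on compound 3 alone. The step of a number no higher from compound 3 to compound 4 (the limit leaves the size open) is expected to be no larger than the usual scatter, in no clear direction. Compound 4 is therefore estimated at 100 ug/mL, with a range from 30 ug/mL to 300 ug/mL, and most likely the assay will again report only a limit.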

Compound 4, half-maximal inhibitory concentration: > 100 ug/mL
Compound 4 was reported as a limit; the forecaster's own chance of this, stated with the estimate: 75%; the middle value lies on the limit itself.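

In this assay compound 4 gives > 100 ug/mL, a limit and not a number. Compound 3 gives > 100 ug/mL, also a limit, so no step can be read between compound 3 and compound 4. Going by these compounds, whether carboxy in place of hydrogen changes the cytotoxicity at all remains open.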